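Swapping the azepane amide for a bicyclic carbocycle

The compounds below may be only part of what the source reports. "The series", "measured", "known", "first", "only" and "open" are said of these compounds alone.

Measured so far:
Compound 1, `O=C([C@H]1CC2CCC1C2)N1CC(c2nc(-c3ccccc3)no2)C1`: 120 nM
Compound 2, `CC1CCCC(C(=O)N2CC(c3nc(-c4cccc(Cl)c4)no3)C2)C1`: 410 nM
Compound 3, `O=C(N1CCCCCC1)N1CC(c2nc(-c3cccc(Cl)c3)no2)C1`: 47 nM

In an assay on HEK293 cells for positive allosteric modulation of metabotropic glutamate receptor 5 (Homo sapiens), read by FLIPR (on this read-out lower numbers stand for an effect already at smaller amounts and higher numbers for an effect only at larger amounts of compound), compound 3 gives the lowest number of the three, with compound 1 nearest and compound 2 furthest away. Going by the values given here, the one step measured within the set, an 8.7-fold lower number from compound 2 to compound 3 (0.94 log units; beyond the scatter), shows that the azepan-1-yl amide gives a clearly lower number than the 3-methylcyclohexyl amide on the same chlorophenyl-bearing core.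

Compound 4, `O=C([C@H]1CC2CCC1C2)N1CC(c2nc(-c3cccc(Cl)c3)no2)C1`, has not yet been measured in this assay. It differs from compound 3 by a group of 7 heavy atoms (7 carbon; 2 five-membered non-aromatic rings of carbon only) in place of a group of 7 heavy atoms (6 carbon, 1 nitrogen; one seven-membered non-aromatic ring with 1 hetero atom), on a carbonyl carbon. Among the compounds with values here, this is the reverse direction of the only relevant step: a ring with nitrogen leaves and a carbon-only ring enters on the carbonyl carbon. The step from compound 2 to compound 3 was modest but beyond the scatter, so a higher number for compound 4 than for compound 3 is the likelier outcome. Compound 1, which carries the same bicyclic amide but an unsubstituted phenyl, gives a number that sits above compound 3, and compound 4 is expected to land in a similar region, with a 2.3-fold higher number from compound 3 to compound 4 (0.37 log units; beyond the scatter). The estimate for compound 4 in this assay is 110 nM, within 40 nM to 300 nM.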

Compound 4, half-maximal effective concentration: 74 nM
Compound 4: the middle estimate sits 1.5-fold (0.17 log units) above what was measured; the range from low to high includes it.
By their numbers in this assay, from the lowest: compounds 3, 4 and 1 (each within the scatter of the next, the first and the last beyond it); then compound 2.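

In this assay, the carbon-only bicyclic group on the carbonyl carbon stays level with azepan-1-yl, a 1.6-fold higher number from compound 3 to compound 4 (0.20 log units; within the scatter), so on this core a nitrogen-containing ring is not required to keep a number in this range. The same bicyclic group remains clearly apart from the 3-methylcyclohexyl group of compound 2, a 5.5-fold lower number from compound 2 to compound 4 (0.74 log units; beyond the scatter), which shows that the earlier gap between compound 2 and compound 3 does not simply separate carbon-only groups from azepan-1-yl: compound 2 and compound 4 both carry carbon-only groups, yet they differ beyond the scatter. The chloro group, new to the bicyclic amide series, makes no clear difference there, a 1.6-fold lower number from compound 1 to compound 4 (0.21 log units; within the scatter), so with this amide the pair shows no effect of chloro in place of hydrogen on an aromatic carbon beyond the scatter.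

Nothing available gives a reason for these steps. Going by these compounds, it remains open how a simple cycloheptyl group, the opposite stereoisomer of the bicyclic group, or fluoro in place of the chloro would read out on this core.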